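The source may hold more compounds than are shown below. What is called first, only, known or untested is meant among the compounds shown, and "the series" means these compounds.

Measured compounds:
compound 1 `CN(C(=O)NC(=O)c1ccc([N+](=O)[O-])cc1)c1nc(C(F)(F)F)c(C(=O)N/N=C/c2ccc([N+](=O)[O-])cc2)s1`: 12.3 ug/mL
compound 2 `CN(C(=O)NC(=O)c1ccc(F)c(F)c1)c1nc(C(F)(F)F)c(C(=O)N/N=C/c2cccc(C(F)(F)F)c2)s1`: 5.6 ug/mL
compound 3 `CN(C(=O)NC(=O)c1ccc(F)c(F)c1)c1nc(C(F)(F)F)c(C(=O)N/N=C/c2ccc([N+](=O)[O-])cc2)s1`: 6.23 ug/mL

Of the compounds shown here, three on one shared core have been tested in a functional assay on HepG2 cells (Homo sapiens) for inhibition, read by MTT assay, with a stated time of 72 h; on this read-out lower numbers stand for stronger inhibition and higher numbers for weaker inhibition. Compound 2 has the lowest of the three numbers, though its gap to compound 3, a 1.1-fold higher number from compound 2 to compound 3 (0.05 log units; within the scatter), lies within the scatter, so no order between those two is claimed; only its gap to compound 1 lies beyond the scatter. From compound 3 to compound 1 the change is 4-nitrophenyl in place of 3,4-difluorophenyl on a carbonyl carbon and the step is a 2.0-fold higher number from compound 3 to compound 1 (0.30 log units; within the scatter).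

Compound 4 `CN(C(=O)NC(=O)c1ccc([N+](=O)[O-])cc1)c1nc(C(F)(F)F)c(C(=O)N/N=C/c2cccc(C(F)(F)F)c2)s1` has not yet been measured in this assay. It differs from compound 2 by 4-nitrophenyl in place of 3,4-difluorophenyl on a carbonyl carbon. The cores of compound 2 and compound 3 differ by 3-(trifluoromethyl)phenyl in place of 4-nitrophenyl on a carbon with a double bond to nitrogen. Since the place of the change reads the same word for word in both pairs, the change from compound 2 to compound 4 is the same change as that from compound 3 to compound 1. The step from compound 2 to compound 4 is therefore expected to be about a 2.0-fold higher number from compound 2 to compound 4 (0.29 log units; within the scatter), resting on the earlier step because a 2.0-fold higher number from compound 3 to compound 1 (0.30 log units; within the scatter). Compound 4 is estimated at 11 ug/mL, with a range expected from 5.5 ug/mL to 22 ug/mL.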

Compound 4, half-maximal inhibitory concentration: 4.73 ug/mL
Beside the measured number, compound 4's estimate is 2.3-fold (0.37 log units) above it; the whole stated range lies above it.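

In this assay, 4-nitrophenyl in place of 3,4-difluorophenyl on a carbonyl carbon gives a 1.2-fold lower number from compound 2 to compound 4 (0.07 log units; within the scatter), and this step does not differ, beyond what two such steps can scatter, from the one seen earlier on the other core: the same change on two cores in this assay, a 2.0-fold higher number (0.30 log units; within the scatter) from compound 3 to compound 1 and a 1.2-fold lower number (0.07 log units; within the scatter) from compound 2 to compound 4, 2.3-fold (0.37 log units) apart, within the scatter of two such steps. The change at the other place, 3-(trifluoromethyl)phenyl in place of 4-nitrophenyl on a carbon with a double bond to nitrogen, gives a 2.6-fold lower number from compound 1 to compound 4 (0.42 log units; beyond the scatter), and it too agrees within the scatter with its counterpart: the same change on two cores in this assay, a 1.1-fold higher number (0.05 log units; within the scatter) from compound 2 to compound 3 and a 2.6-fold higher number (0.42 log units; beyond the scatter) from compound 4 to compound 1, 2.3-fold (0.37 log units) apart, within the scatter of two such steps. The four compounds are therefore compatible with each change carrying from one core to the other, but they do not prove it, since each change rests on a single pair of steps and a modest dependence on the core cannot be excluded.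

The compounds shown leave open whether this holds for other kinds of group at these two places. On these data alone, an amine, a carboxylic acid or a longer alkyl chain in place of either phenyl group remains untested here.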